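This account rests on a few compounds, and the source may have more. Where it says the series, first, only, none or still open, it means among the compounds named here.

- compound 1 `COc1cc(/C=C/C(=O)OCCCCOc2no[n+]([O-])c2S(=O)(=O)c2ccccc2)ccc1O`: 400 nM
- compound 2 `COc1cc(/C=C/C(=O)OCCCCCCO[N+](=O)[O-])ccc1O`: > 50000 nM
- compound 3 `O=C(/C=C/c1ccc(OCCCCO[N+](=O)[O-])c(O)c1)OCCCCO[N+](=O)[O-]`: > 50000 nM

All three compounds were tested in a functional assay on M14 cells (Homo sapiens) for cytotoxicity, read by resazurin assay, with a stated time of 72 h; a higher number here means a weaker inhibitor, a lower number a stronger inhibitor. Within the data shown here, compound 1 is the only one with a measured number, 400 nM. Compound 2 stands at > 50000 nM, which is a limit of the assay and not a number. Compound 3 also gives only a limit, > 50000 nM. Together these results show (the limit of > 50000 nM in this assay, at which 2 of the 3 values shown sit).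

Compound 4 `COc1cc(/C=C/C(=O)OCCCCCO[N+](=O)[O-])ccc1O` differs from compound 2 in one place: nitrooxy in place of (nitrooxy)methyl on a saturated chain carbon, five bonds along the chain from an oxygen next to a carbonyl group.

Among the measured compounds shown here, no two measured compounds differ in only one place, so there is no direct precedent for the size of this step in this assay. No change beyond the usual scatter is expected. This expectation rests on compound 2, whose result is the limit > 50000 nM. The expected step is a number no higher from compound 2 to compound 4 (the limit leaves the size open). For compound 4, the estimated value is 50000 nM, with an expected range of 20000 nM to 100000 nM.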

Compound 4, half-maximal inhibitory concentration: 24500 nM
The estimate for compound 4 lay 2.0-fold (0.31 log units) above the measured number; low and high end bracket the measured number.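

In this assay, compound 4 gives a measured number, 24500 nM. This makes it the only compound shown carrying nitrooxy that does not rest at a limit. Compound 2 gives only a limit, > 50000 nM. The change at this saturated chain carbon, nitrooxy in place of (nitrooxy)methyl, is an at least 2.0-fold lower number from compound 2 to compound 4 (0.30 log units; that floor lies within the scatter), and its true size stays open because the starting value is only a limit: the limit of > 50000 nM in this assay, at which 2 of the 4 values shown sit.

The compounds shown leave open whether a shorter chain carrying nitrooxy would move the number further, and what an amine or a carboxylic acid in place of nitrooxy would do on this carbon. Compound 1 differs from compound 4 in more than one place, so the gap between their values cannot be tied to any single change.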